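The compounds below may be only part of what the source reports. "The series", "measured", "known", "first", "only" and "open" are said of these compounds alone.

Measured compounds in an assay on HEK293 cells for agonist activity at Toll-like receptor 8 (Homo sapiens), read by a luciferase reporter, with a stated time of 6 h; on this read-out lower numbers stand for an effect already at smaller amounts and higher numbers for an effect only at larger amounts of compound:
- compound 1, `CCCCNc1nc(N)nc2c1CN(Cc1ccccc1)CC2`: 0.06 uM
- compound 2, `CCCCNc1nc(N)nc2c1CN(Cc1ccc(C(F)(F)F)cc1)CC2`: 0.23 uM

Within the data shown here, compound 1 holds the lowest of the two numbers so far; its nearest neighbour is compound 2, and the step of a 3.8-fold higher number from compound 1 to compound 2 (0.58 log units; beyond the scatter) lies beyond the scatter. That step concerns only a substituent on the benzyl ring of compound 1, with the benzyl itself left in place.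

Compound 3, `CCCCNc1nc(N)nc2c1CN(C(=O)c1csc(C)n1)CC2`, has not been measured. It differs from compound 1 in one place: (2-methyl-1,3-thiazol-4-yl)carbonyl in place of benzyl on an amine nitrogen in a ring. The whole benzyl is exchanged, and what enters carries a carbonyl and a five-membered aromatic ring with two hetero atoms, with three hydrogen-bond acceptors where the benzyl had none.

Among the measured compounds shown here, no measured step bears directly on this exchange. The step of a 3.8-fold higher number from compound 1 to compound 2 (0.58 log units; beyond the scatter) shows only that this assay responds to a change on the benzyl, and that the change there moved the number upward. A larger move in either direction is possible for compound 3. The expectation for compound 3 is a step of a 5.0-fold higher number from compound 1 to compound 3 (0.70 log units; beyond the scatter), with a wide range. For compound 3 the estimated value in this assay is 0.3 uM, between 0.05 uM and 2 uM.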

Compound 3, minimum effective concentration: 1.8 uM
Estimate against measurement, compound 3: 6.0-fold (0.78 log units) below; low and high end bracket the measured number.
By their numbers in this assay, from the lowest: compound 1; then compound 2; then compound 3.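

In this assay, putting (2-methyl-1,3-thiazol-4-yl)carbonyl in place of benzyl on an amine nitrogen in a ring gives a 30-fold higher number from compound 1 to compound 3 (1.48 log units; beyond the scatter) and is a large step, where the earlier change on the benzyl ring was a modest one. This position therefore responds to exchange of the whole group and not only to a substituent on the benzyl ring, and on this evidence benzyl is the better of the two groups on the shared core. A minimum effective concentration is still recorded for compound 3, so an effect in this read-out does not depend on the benzyl, and nothing available accounts for the rise in the number.

The exchange alters two things at once, the carbonyl on the amine nitrogen and the aromatic ring, and the compounds shown cannot separate them: a benzoyl group would keep the carbonyl with the six-membered carbon ring, and a (2-methyl-1,3-thiazol-4-yl)methyl group would keep the five-membered ring without the carbonyl. From the compounds shown here alone, it also remains open how a simple alkyl chain or a phenethyl group at this position would compare with benzyl.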